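Adding a Third Methoxy Group to the Allyl Triazole

The source may report more compounds than this note shows. Statements on the series, on what has been measured and on what is new or still open speak of the compounds shown alone.

Of the compounds shown here, two built on a shared core have been tested in a functional assay on the whole organism (strain albino) for inhibition, with Rattus norvegicus as the target, read by paw edema, with stated times of 30 min and 5 h, at a dose of 0.28 mmol/kg by the oral route; on this read-out higher numbers stand for more inhibition at the one dose given (going by the name of the read-out) and lower numbers for less inhibition. Compound 1 `CCn1c(SCC(=O)Nc2ccc(/C(C)=N/O)cc2)nnc1-c1cc(OC)c(OC)c(OC)c1` gives 61%. Compound 2 `C=CCn1c(SCC(=O)Nc2ccc(/C(C)=N/O)cc2)nnc1-c1ccc(OC)c(OC)c1` gives 79%, the higher of the two numbers, and its gap to compound 1 lies beyond the usual scatter of repeated measurements. Compounds 1 and 2 differ from each other in more than one place, so their two values alone do not isolate any single structural step.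

Compound 3 `C=CCn1c(SCC(=O)Nc2ccc(/C(C)=N/O)cc2)nnc1-c1cc(OC)c(OC)c(OC)c1` has not yet been measured. Relative to compound 2, the change is methoxy in place of hydrogen on an aromatic carbon; the incoming group sits ortho to a methoxy group and meta to a large group on the six-membered aromatic ring of carbon only. Compound 3 thus carries the same three methoxy groups as compound 1 while keeping the allyl chain of compound 2. A modest fall is expected because compound 1 gives 61% whereas compound 2 gives 79%, although that comparison also carries the second difference. The step expected is a number 9 percentage points lower from compound 2 to compound 3 (within the scatter), close to the edge of the scatter. Compound 3 is estimated to give about 70%, within a range from 55% to 85%.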

Compound 3, a percentage reported as inhibition, in the whole organism at one dose (the size of the read-out at that dose, not a potency): 64%
For compound 3 the middle estimate is 6 percentage points above the measured one, within the range that was stated.
By their numbers in this assay, from the lowest: compounds 1 and 3 (each within the scatter of the next); then compound 2.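

With the allyl chain held fixed, placing methoxy in place of hydrogen on this aromatic carbon, ortho to a methoxy group and meta to a large group, has a clear cost in this assay: the read-out shows a number 15 percentage points lower from compound 2 to compound 3 (beyond the scatter), so at the one dose given this position does not take the extra group without a loss of inhibition. The second comparison isolates the chain on the aromatic nitrogen, where vinyl in place of methyl on the saturated chain carbon gives a number 3 percentage points higher from compound 1 to compound 3 (within the scatter), so on the ring with three methoxy groups, the allyl and ethyl chains cannot be told apart in this read-out, and of the two single changes now seen, only the methoxy step lies beyond the scatter. Nothing measured here explains why the added methoxy group lowers inhibition.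

The compounds shown leave open whether a smaller or different group on this aromatic carbon, such as a fluorine atom or a hydroxyl group, would also lower the number. Also open, on these data alone, is whether the chain swap stays within the scatter on the ring of compound 2, and how a longer chain on the aromatic nitrogen would behave.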